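Notes on the aryl change from compound 3 to compound 4

The source may report more compounds than this note shows. Statements on the series, on what has been measured and on what is new or still open speak of the compounds shown alone.

Measured so far in a functional assay on U-87MG ATCC cells (Homo sapiens) for cytotoxicity, read by MTT assay, with a stated time of 72 h; on this read-out lower numbers stand for stronger inhibition and higher numbers for weaker inhibition:
- Compound 1 `CN(C)CCn1cnnc1-c1cc(Oc2ccc(NC(=O)N/N=C/c3ccc(O)c(O)c3)cc2F)ccn1`: > 100000 nM, a limit of the assay, not a number.
- Compound 2 `CN(C)CCn1cnnc1-c1cc(Oc2ccc(NC(=O)N/N=C/c3ccc(O)cc3)cc2F)ccn1`: 7750 nM.
- Compound 3 `CN(C)CCn1cnnc1-c1cc(Oc2ccc(NC(=O)N/N=C/c3c[nH]c4ccccc34)cc2F)ccn1`: 690 nM.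

Compound 3 holds the lowest number among the two numbers measured; its nearest neighbour is compound 2, the step being an 11-fold lower number from compound 2 to compound 3 (1.05 log units; beyond the scatter). Compound 1 sits at the limit (the limit of > 100000 nM in this assay, at which 1 of the 3 values shown sits), so its distance from the others is only bounded: an at least 140-fold lower number from compound 1 to compound 3 (2.16 log units; beyond the scatter) and an at least 12-fold lower number from compound 1 to compound 2 (1.11 log units; beyond the scatter).

Compound 4 `CN(C)CCn1cnnc1-c1cc(Oc2ccc(NC(=O)N/N=C/c3ccc(F)cc3)cc2F)ccn1` differs from compound 3 as follows: 4-fluorophenyl in place of 1H-indol-3-yl on a carbon with a double bond to nitrogen. The measured steps bearing on this are those that replace or strip the aryl on the carbon with a double bond to nitrogen: the steps from compound 2 to compound 3 and from compound 1 to compound 2, both large. Compound 4 carries a six-membered ring of carbon only, like compound 2, and lacks the hydroxy groups of compound 1 and compound 2. A rise in the number relative to compound 3 is therefore expected, of moderate size, a 4.3-fold higher number from compound 3 to compound 4 (0.64 log units; beyond the scatter). Compound 4 is estimated at 3000 nM, within a range of 700 nM to 15000 nM.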

Compound 4, half-maximal inhibitory concentration: 2310 nM
For compound 4 the middle estimate is 1.3-fold (0.11 log units) above the measured one, and the stated range covers the measured number.
By their numbers in this assay, from the lowest: compound 3; then compound 4; then compound 2. At a limit, above all of these: compound 1.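

At this position on the carbon with a double bond to nitrogen, a hydroxy group on the six-membered ring is not needed for cytotoxicity: with fluoro in its place, the result is a 3.4-fold lower number from compound 2 to compound 4 (0.53 log units; beyond the scatter). The 4-fluorophenyl does not match the bicyclic 1H-indol-3-yl, however, with a 3.3-fold higher number from compound 3 to compound 4 (0.52 log units; beyond the scatter), so the indole stays ahead of every six-membered aryl shown. Compound 1 stands at a limit and not at a number, so an at least 43-fold lower number from compound 1 to compound 4 (1.63 log units; beyond the scatter) is only bounded: the limit of > 100000 nM in this assay, at which 1 of the 4 values shown sits.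

As far as these compounds go, whether the gain in compound 4 comes from the fluoro itself or only from the loss of hydroxy stays open, and a plain phenyl, a 4-chlorophenyl or a 4-methoxyphenyl would separate the two. Equally open, from the compounds shown here alone, is what the indole's ring nitrogen contributes, which a 1-methylindol-3-yl or a benzofuran-3-yl would test.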